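The source may hold more compounds than are shown below. What is called first, only, known or untested is meant among the compounds shown, and "the series" means these compounds.

Compound 1, `COc1ccccc1N1CCN(CC(O)Cn2c([N+](=O)[O-])cnc2C)CC1`, in a toxicity assay on HeLa cells (Homo sapiens) for cytotoxicity, read by MTT assay, with a stated time of 24 h (a higher number here means a weaker inhibitor, a lower number a stronger inhibitor), gives 4390000 nM.
Compound 2, `Cc1ncc([N+](=O)[O-])n1CC(O)CN1CCN(c2cccc(Cl)c2)CC1`, in this assay gives 1440000 nM.
Compound 3, `COc1ccccc1N1CCN(C(=S)SCC(O)Cn2cc([N+](=O)[O-])nc2C)CC1`, in this assay reaches only a limit of the assay, > 5000000 nM.

Compounds 1 and 2 share a core and differ in one place: 3-chlorophenyl in place of 2-methoxyphenyl on an amine nitrogen in a ring. That change gave a 3.0-fold lower number from compound 1 to compound 2 (0.48 log units; beyond the scatter), so compound 2 is the more cytotoxic of the two. Compound 3 carries a different core, and the difference between the two cores is not broken down here. For the measured compounds named here, compound 4, `Cc1nc([N+](=O)[O-])cn1CC(O)CSC(=S)N1CCN(c2cccc(Cl)c2)CC1`, is not yet measured; it differs from compound 3 by 3-chlorophenyl in place of 2-methoxyphenyl on an amine nitrogen in a ring, the same change as the one from compound 1 to compound 2.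

Expected for compound 4 in this assay is an at least 1.4-fold lower number from compound 3 to compound 4 (0.15 log units; that floor lies within the scatter), a step of about the size seen from compound 1 to compound 2 in a 3.0-fold lower number from compound 1 to compound 2 (0.48 log units; beyond the scatter), with the caution that compound 3 sits at the limit of > 5000000 nM in this assay, at which 1 of the 3 values shown sits, so the starting point is uncertain. Compound 4 is therefore estimated at 3500000 nM, with a likely range from 1200000 nM to 10000000 nM.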

Compound 4, half-maximal inhibitory concentration: 1740000 nM
Beside the measured number, compound 4's estimate is 2.0-fold (0.30 log units) above it, within the range that was stated.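

Putting 3-chlorophenyl in place of 2-methoxyphenyl on the ring nitrogen in this assay gave an at least 2.8-fold lower number from compound 3 to compound 4 (0.45 log units; beyond the scatter), so the number fell on the second core as it had on the first: the same change on two cores in this assay, a 3.0-fold lower number (0.48 log units; beyond the scatter) from compound 1 to compound 2 and an at least 2.8-fold lower number (0.45 log units; beyond the scatter) from compound 3 to compound 4; the limit leaves it open whether they differ. Compound 3 reaches only a limit of the assay, > 5000000 nM. As far as these compounds go, the change therefore carries over in direction between these two cores, but the true size of the second step is unknown, so it cannot be said that the change has the same size on both, and two cores are too few to make a rule for the whole series.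

Still open, from the compounds shown here alone, is whether other groups on that ring nitrogen, such as a benzyl group or a simple methyl, would move the number further than 3-chlorophenyl does. Also open is whether the same change would lower the number on a core with a longer chain or with an amide in place of the chain shown here.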